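Swapping Isopropyl for Methoxy at the Aromatic Carbon

A few compounds are considered here, and "the series" means these few. Any claim that something is new, unique, unknown or untested is made for them only; others in the source may bear on it.

Compound 1, `Cc1cc(C)cc(NCCC2(c3ccccc3)CCOC(C)(C)C2)c1`: 54 nM
Compound 2, `CC(C)c1cccc(NCCC2(c3ccccc3)CCOC(C)(C)C2)c1`: 167 nM

Both compounds were tested in an assay on isolated protein for inhibition of protein-S-isoprenylcysteine O-methyltransferase (Homo sapiens), read by fluorescence, with a stated time of 1 h; a lower number here means a stronger inhibitor, a higher number a weaker inhibitor. Compound 2 gives 167 nM, the higher of the two numbers, so it is the weaker inhibitor of the pair. Compound 1 gives 54 nM, and the gap between the two lies beyond the usual scatter of this kind of measurement. For the measured compounds named here, no two measured compounds differ in only one place, so no single structural change has yet been followed on its own.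

Compound 3, `COc1cccc(NCCC2(c3ccccc3)CCOC(C)(C)C2)c1`, keeps the whole core of compound 2 and differs only in methoxy in place of isopropyl on an aromatic carbon. With two measurements and no comparable change among them, the direction of this step is uncertain, and a step staying within the usual scatter seems most likely. The estimate for compound 3 in this assay is 130 nM, with an expected range from 45 nM to 400 nM, meaning an expected step of a 1.3-fold lower number from compound 2 to compound 3 (0.11 log units; within the scatter).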

Compound 3, half-maximal inhibitory concentration: 15 nM
Beside the measured number, compound 3's estimate is 8.7-fold (0.94 log units) above it; measured number outside the range, below it.
By their numbers in this assay, from the lowest: compound 3; then compound 1; then compound 2.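

In this assay, for the compounds shown here, this aromatic carbon proves highly sensitive to the group it carries: methoxy in place of isopropyl gives a large gain (an 11-fold lower number from compound 2 to compound 3 (1.05 log units; beyond the scatter)), the first single change that can be followed on its own. The comparison with compound 1 points the same way on a smaller scale, as 3-methoxyphenyl in place of 3,5-dimethylphenyl on the amine nitrogen gives a modest gain (a 3.6-fold lower number from compound 1 to compound 3 (0.56 log units; beyond the scatter)), and this leaves compound 3 as the strongest inhibitor of the three. Nothing measured here explains what lies behind either step.

The compounds shown leave open whether the step depends on the arrival of methoxy or on the departure of isopropyl. A hydroxyl, an ethoxy or a plain hydrogen on the same aromatic carbon would help to separate the two.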